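Extending the dimethylamino side chain

The source may hold more compounds than are shown below. What is called first, only, known or untested is meant among the compounds shown, and "the series" means these compounds.

Compound 1 `COc1ncc(-c2ccc3ncnc(NCc4ccncc4)c3c2)cc1NS(=O)(=O)c1ccc(F)cc1F`: 6210 nM
Compound 2 `COc1ncc(-c2ccc3ncnc(NCCN(C)C)c3c2)cc1NS(=O)(=O)c1ccc(F)cc1F`: 620 nM

Both values come from a functional assay on SNU-638 cells (Homo sapiens) for antiproliferative activity, read by sulforhodamine B assay, with a stated time of 72 h; on this read-out higher numbers stand for weaker inhibition and lower numbers for stronger inhibition. Compound 2 holds the lower of the two numbers at 620 nM, so it is the stronger inhibitor so far. The next structure is compound 3 `COc1ncc(-c2ccc3ncnc(NCCCN(C)C)c3c2)cc1NS(=O)(=O)c1ccc(F)cc1F`, which differs from compound 2 as follows: (dimethylamino)methyl in place of dimethylamino on a saturated chain carbon, two bonds along the chain from a nitrogen on an aromatic ring. Put simply, (dimethylamino)methyl stands in place of dimethylamino on a saturated chain carbon, two bonds along the chain from a nitrogen on an aromatic ring. Going by the values given here, the only measured step, a 10-fold lower number from compound 1 to compound 2 (1.00 log units; beyond the scatter), replaced pyridin-4-yl with (dimethylamino)methyl, so it bears on this change only loosely. Among the compounds with values here, no measured pair shows what lengthening this chain does, which leaves the expectation uncertain. With the dimethylamino end kept, the expected change is small, a 1.2-fold higher number from compound 2 to compound 3 (0.08 log units; within the scatter), and none beyond the scatter is anticipated. For compound 3 the estimate is 750 nM, with an expected range of 280 nM to 2000 nM.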

Compound 3, half-maximal inhibitory concentration: 1260 nM
Beside the measured number, compound 3's estimate is 1.7-fold (0.23 log units) below it; the range from low to high includes it.
By their numbers in this assay, from the lowest: compound 2; then compound 3; then compound 1.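

In this assay, the length of the chain proves to matter, even with the dimethylamino end unchanged: adding one chain carbon gives a 2.0-fold higher number from compound 2 to compound 3 (0.31 log units; beyond the scatter), so 2-(dimethylamino)ethyl outperforms 3-(dimethylamino)propyl at this position. The longer chain still improves on the pyridin-4-yl group, with a 4.9-fold lower number from compound 1 to compound 3 (0.69 log units; beyond the scatter), so a dimethylamino-ended chain of either length gives the lower number of this comparison. Nothing available here explains why one added carbon shifts the value.

Three compounds leave open whether a still longer chain ending in dimethylamino would continue this rise in the number. They also leave open how a morpholine ring or a primary amine at the chain end would compare with dimethylamino on the 2-(dimethylamino)ethyl chain.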